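Removing the methoxy group from a furan bis-amidine

The compounds below may be only part of what the source reports. "The series", "measured", "known", "first", "only" and "open" are said of these compounds alone.

Measured compounds:
Compound 1, `N=C(N)c1ccc(-c2ccc(-c3cc(Cl)cc(Cl)c3)s2)s1`, in a functional assay on UACC-257 cells (Homo sapiens) for inhibition, read by sulforhodamine B assay, with a stated time of 48 h (a higher number here means a weaker inhibitor of growth, a lower number a stronger inhibitor of growth), gives 2050 nM.
Compound 2, `COc1ccc(-c2ccc(-c3ccc(C(=N)N)o3)o2)cc1`, in this assay gives 11100 nM.
Compound 3, `N=C(N)c1ccc(-c2ccc(-c3ccc(Cl)cc3)s2)s1`, in this assay gives 2780 nM.

Among these three numbers compound 2 stands highest, the weakest inhibitor of growth in this assay; its nearest neighbour is compound 3, and compound 1 lies furthest from it, both gaps beyond the scatter. Compound 4, `N=C(N)c1ccc(-c2ccc(-c3ccccc3)o2)o1`, differs from compound 2 in one place: hydrogen in place of methoxy on an aromatic carbon. Within the data shown here, no measured pair shows the effect of this change, so only a modest step is expected, with no clear direction beyond the scatter. Compound 4 is therefore estimated to give 12000 nM in this assay, within 5000 nM to 30000 nM, an expected step of a 1.1-fold higher number from compound 2 to compound 4 (0.03 log units; within the scatter).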

Compound 4, concentration for 50% growth inhibition: 2520 nM
The estimate for compound 4 lay 4.8-fold (0.68 log units) above the measured number; the measured number lies below the stated range.
By their numbers in this assay, from the lowest: compounds 1, 4 and 3 (each within the scatter of the next); then compound 2.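

In this assay, the place para to a large group proves sensitive to this change: hydrogen in place of methoxy gives a 4.4-fold lower number from compound 2 to compound 4 (0.64 log units; beyond the scatter). Here methoxy goes with the weaker inhibitor of growth and hydrogen with the stronger, a one-place comparison that the earlier compounds could not give. No measured property bears on this step. The compounds shown leave open whether a hydroxyl or an ethoxy group at this place would stand with methoxy or with hydrogen. They also leave open whether the step holds outside the core of compound 2.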